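The source may report more compounds than this note shows. Statements on the series, on what has been measured and on what is new or still open speak of the compounds shown alone.

Compound 1 `O=C(Nc1ccc(-c2noc(-c3cccc(NS(=O)(=O)c4ccccc4)c3)n2)c(Cl)c1)c1cccnc1` gives a limit of > 10000 nM in a functional assay on MDA-MB-231 cells (Homo sapiens) for antiproliferative activity, read by MTT assay, with a stated time of 72 h; a lower number here means a stronger inhibitor, a higher number a weaker inhibitor. Compound 2 `COc1cccc(S(=O)(=O)Nc2cccc(-c3nc(-c4ccc(NC(=O)c5cccnc5)cc4Cl)no3)c2)c1` likewise gives a limit of > 10000 nM in this assay. Compound 3 `NS(=O)(=O)c1ccc(NC(=O)Nc2cccc(-c3nc(-c4ccc(NC(=O)c5cccnc5)cc4Cl)no3)c2)cc1` also gives only a limit, > 10000 nM, in this assay.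

Compound 3 thus stands with the other two measured compounds at the assay limit, and no number is known for any of them (the limit of > 10000 nM in this assay, at which 3 of the 3 values shown sit). Among the compounds with values here, the single change between measured compounds, a step that the two limits leave unreadable from compound 1 to compound 2, joins two limits and cannot be read as a step of any size or direction.

Compound 4 `C#Cc1cccc(NC(=O)Nc2cccc(-c3nc(-c4ccc(NC(=O)c5cccnc5)cc4Cl)no3)c2)c1` differs from compound 3 in one place: 3-ethynylphenyl in place of 4-sulfamoylphenyl on an amide-type nitrogen. Within the data shown here, no measured step bears on this exchange, since the only measured change concerns a methoxy group on another part of the molecule and is itself unreadable. With all three measured values at the limit, the expectation for compound 4 is that it too most likely returns only a limit, so the estimated step that the limit leaves unreadable from compound 3 to compound 4 is set near zero with a wide range. Compound 4 is therefore expected at about 15000 nM, between 3000 nM and 60000 nM.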

Compound 4, half-maximal inhibitory concentration: > 10000 nM
Compound 4 was reported as a limit; the forecaster's own chance of this, stated with the estimate: 70%; the middle value does not contradict the limit.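

Compound 4 gives only a limit, as do compounds 1, 2 and 3, so none of the steps joining compound 4 to them can be read in this assay: (the limit of > 10000 nM in this assay, at which 4 of the 4 values shown sit). The compounds shown leave open how their differing groups rank against one another, and which group on the shared core would give a measurable value.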